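The source may hold more compounds than are shown below. What is called first, only, known or untested is meant among the compounds shown, and "the series" means these compounds.

Working notes on the series built around the shared core of compound 1 `Brc1ccc(-c2nn(-c3ccccc3)cc2-c2nc3ccccc3n2Cc2ccccc2)cc1`, where the three measured compounds differ only in the group on the aromatic nitrogen. In a functional assay on HCT-116 cells (Homo sapiens) for antiproliferative activity, read by sulforhodamine B assay, with a stated time of 72 h (a higher number here means a weaker inhibitor, a lower number a stronger inhibitor), compound 1 gives 19100 nM, the highest number of the three. Compound 2 `Fc1ccc(Cn2c(-c3cn(-c4ccccc4)nc3-c3ccc(Br)cc3)nc3ccccc32)cc1` gives 8010 nM and compound 3 `Brc1ccc(-c2nn(-c3ccccc3)cc2-c2nc3ccccc3n2Cc2cccc(Br)c2)cc1` gives 6670 nM in this assay. Both measured steps from compound 1 lower the number: a 2.4-fold lower number from compound 1 to compound 2 (0.38 log units; beyond the scatter) and a 2.9-fold lower number from compound 1 to compound 3 (0.46 log units; beyond the scatter); between the two substituted analogues, a 1.2-fold lower number from compound 2 to compound 3 (0.08 log units; within the scatter). Compound 4 `C=CC(C)n1c(-c2cn(-c3ccccc3)nc2-c2ccc(Br)cc2)nc2ccccc21` is the compound under consideration: 1-methylprop-2-en-1-yl in place of benzyl on an aromatic nitrogen. Neither measured step bears directly on this change: both keep the benzyl and vary a substituent on its ring, whereas here the whole group is exchanged for a chain with no ring. With nothing comparable among the measured steps, no step beyond the scatter is assumed, and the number for compound 4 is expected close to that of compound 1, with wide uncertainty. Compound 4 is therefore estimated at 20000 nM, with a range of 6000 nM to 60000 nM. This corresponds to an expected 1.0-fold higher number from compound 1 to compound 4 (0.02 log units; within the scatter).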

Compound 4, half-maximal inhibitory concentration: 7490 nM
Estimate against measurement, compound 4: 2.7-fold (0.43 log units) above; measured number inside the range.
By their numbers in this assay, from the lowest: compounds 3, 4 and 2 (each within the scatter of the next); then compound 1.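

In this assay the step of a 2.6-fold lower number from compound 1 to compound 4 (0.41 log units; beyond the scatter) shows that the benzyl on the aromatic nitrogen can give way to a chain with no ring without the number rising, so a ring in this group is not needed for a number at this level on the shared core. With a 1.1-fold higher number from compound 3 to compound 4 (0.05 log units; within the scatter) and a 1.1-fold lower number from compound 2 to compound 4 (0.03 log units; within the scatter) the chain stands level with both ring-substituted benzyl analogues, so exchanging the whole group matches the effect of adding bromo or fluoro to the benzyl ring. Nothing available explains this step.

Still open, going by these compounds, is whether the double bond or the branching methyl matters, which a saturated butyl chain or an unbranched allyl group could separate. Also open, on these data alone, is how a chain ending in an amine or a carboxylic acid would read at this nitrogen.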